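Clearance notes: from compound 2 to compound 3

A few compounds are considered here, and "the series" means these few. Any claim that something is new, unique, unknown or untested is made for them only; others in the source may bear on it.

Measured in an in vitro ADME assay on microsomes from liver (Homo sapiens) for metabolic stability, in the presence of a further agent that is not named here; on this read-out higher numbers stand for fast clearance and lower numbers for slow clearance:
- compound 1 `N#Cc1ccc2c(c1)cc(C(=O)NCCC(O)C(F)(F)F)n2Cc1cccc(OC(F)(F)F)c1`: 31 mL.min-1.g-1
- compound 2 `N#Cc1ccc2c(c1)cc(C(=O)NCCC1(O)CCC1)n2Cc1cccc(OC(F)(F)F)c1`: < 6 mL.min-1.g-1 (a limit)

Compound 2 stands at the limit of < 6 mL.min-1.g-1 in this assay, at which 1 of the 2 values shown sits, so only a limit is known for it. Compound 3 `CC(O)C1(CNC(=O)c2cc3cc(C#N)ccc3n2Cc2cccc(OC(F)(F)F)c2)CCCC1` carries this change: a group of 8 heavy atoms (7 carbon, 1 oxygen; one five-membered non-aromatic ring of carbon only) in place of a group of 6 heavy atoms (5 carbon, 1 oxygen; one four-membered non-aromatic ring of carbon only), on a saturated chain carbon bound to an amide-type nitrogen, on a saturated chain carbon bound to an amide-type nitrogen. For the measured compounds named here, one measured step bears on this, and only indirectly: an at least 5.1-fold lower number from compound 1 to compound 2 (0.71 log units; beyond the scatter) shows that a change of group on this chain can move this assay beyond the scatter. A modest rise in the number is therefore expected, though a result at the limit remains possible. The expected step is an at least 1.6-fold higher number from compound 2 to compound 3 (0.22 log units; that floor lies within the scatter). The estimate for compound 3 is 10 mL.min-1.g-1, ranging from 4 mL.min-1.g-1 to 28 mL.min-1.g-1.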

Compound 3, intrinsic clearance in microsomes: 9 mL.min-1.g-1
For compound 3 the middle estimate is 1.1-fold (0.05 log units) above the measured one; measured number inside the range.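

In this assay, the group with the five-membered carbon ring also gives a 3.4-fold lower number from compound 1 to compound 3 (0.54 log units; beyond the scatter), so a lower number than that of compound 1 is not confined to the (1-hydroxycyclobutyl)methyl group. The other step, an at least 1.5-fold higher number from compound 2 to compound 3 (0.17 log units; that floor lies within the scatter), rests on a limit and gives a floor, not a size: the limit of < 6 mL.min-1.g-1 in this assay, at which 1 of the 3 values shown sits.

Open, on these data alone, is how far the two carbocyclic groups truly differ in this read-out. Also open, as far as these compounds go, is what an amine or a carboxylic acid in place of the hydroxyl on this chain would give.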